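A few compounds are considered here, and "the series" means these few. Any claim that something is new, unique, unknown or untested is made for them only; others in the source may bear on it.

Measured so far in a functional assay on HCT-116 cells (Homo sapiens) for cytotoxicity, read by MTT assay, with a stated time of 72 h; on this read-out lower numbers stand for stronger inhibition and higher numbers for weaker inhibition:
compound 1 `Nc1ccccc1NC(=O)c1ccc(NC(=S)NCc2cccc(F)c2)cc1`: 5900 nM
compound 2 `Nc1ccccc1NC(=O)c1ccc(NC(=S)NCc2cccnc2)cc1`: 1000 nM
compound 3 `Nc1ccccc1NC(=O)c1ccc(NC(=S)NCc2cncc(F)c2)cc1`: 15000 nM

Compound 3 has the highest number of the three, and so is the weakest here. Its gaps to the other two both lie beyond the scatter. Compound 4 `Cc1ccc(CNC(=S)Nc2ccc(C(=O)Nc3ccccc3N)cc2)cn1` has not yet been measured. It carries 6-methylpyridin-3-yl in place of 5-fluoropyridin-3-yl on a saturated chain carbon bound to an amide-type nitrogen. The fluoro leaves and a methyl enters.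

The most relevant evidence is a 15-fold higher number from compound 2 to compound 3 (1.18 log units; beyond the scatter), a large step. Among the compounds with values here, the only change in that step is fluoro in place of hydrogen on an aromatic carbon. The other two steps, a 5.9-fold lower number from compound 1 to compound 2 (0.77 log units; beyond the scatter) and a 2.5-fold higher number from compound 1 to compound 3 (0.41 log units; beyond the scatter), are modest and run in opposite directions, so small changes to this ring can matter. Within the data shown here, no measured compound carries a methyl, which leaves its contribution unknown. Losing the fluoro points toward compound 2 at 1000 nM, but a full return to that value cannot be assumed. A modest-to-large move toward a lower number is therefore expected. The expected change is a 5.0-fold lower number from compound 3 to compound 4 (0.70 log units; beyond the scatter) in this estimate. For compound 4 the estimated value is 3000 nM, with an expected range from 800 nM to 11000 nM.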

Compound 4, half-maximal inhibitory concentration: 11000 nM
Estimate against measurement, compound 4: 3.7-fold (0.56 log units) below; the range from low to high includes it.
By their numbers in this assay, from the lowest: compound 2; then compounds 1, 4 and 3 (each within the scatter of the next, the first and the last beyond it).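

In this assay, within the data shown here, the new result shows that fluoro is not the only group that raises the number on this ring: a methyl in place of a hydrogen gives an 11-fold higher number from compound 2 to compound 4 (1.04 log units; beyond the scatter) and so brings a large loss of the same kind. Exchanging 5-fluoropyridin-3-yl for 6-methylpyridin-3-yl gives a 1.4-fold lower number from compound 3 to compound 4 (0.13 log units; within the scatter) and exchanging 3-fluorophenyl for 6-methylpyridin-3-yl gives a 1.9-fold higher number from compound 1 to compound 4 (0.27 log units; within the scatter), so neither exchange separates the two compounds it joins in this test. Among these four compounds, only compound 2, whose pyridin-3-yl ring carries neither fluoro nor methyl, stands apart with the lowest number, and both groups added to that ring give up this advantage.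

On these data alone, it remains open whether any group on this ring can be tolerated, for example a hydroxyl, a methoxy or an amine, or whether a chloro or an ethyl would behave like the fluoro and the methyl. No measurement shown here explains why either added group raises the number.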